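Compound 3 to compound 4: replacing the ring substituent

The source may hold more compounds than are shown below. What is called first, only, known or untested is meant among the compounds shown, and "the series" means these compounds.

In a physicochemical assay for solubility, using the shake flask method, in simulated intestinal fluid, measured as kinetic solubility, with a stated time of 20 h, at pH 6.5 (a higher number here means a more soluble compound, a lower number a less soluble compound), compound 1 `FC(F)(F)c1ccc(Nc2cc3[nH]c(C4CCCC4)nc3cn2)nc1` gives 85000 nM, compound 2 `FC1(F)CCC(c2nc3cnc(Nc4ccc(C(F)(F)F)cn4)cc3[nH]2)C1` gives 163000 nM and compound 3 `CC1(c2nc3cnc(Nc4ccc(C(F)(F)F)cn4)cc3[nH]2)CC1` gives 179000 nM. Compound 3 shares the top of this small set with compound 2: a 1.1-fold higher number from compound 2 to compound 3 (0.04 log units; within the scatter). Its margin over the cyclopentyl compound is small: a 2.1-fold higher number from compound 1 to compound 3 (0.32 log units; beyond the scatter).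

Compound 4 `FC1(F)CCC(c2nc3cnc(Nc4ccc(C(F)(F)F)cn4)cc3[nH]2)CC1` is not yet measured. It carries 4,4-difluorocyclohexyl in place of 1-methylcyclopropyl on an aromatic carbon. Among the measured compounds shown here, no measured step involves a six-membered ring, so the guidance is indirect. For the measured compounds named here, the one step beyond the scatter is the change from cyclopentyl to 1-methylcyclopropyl, a 2.1-fold higher number from compound 1 to compound 3 (0.32 log units; beyond the scatter), and compound 4 moves away from 1-methylcyclopropyl to a larger ring. That points to some loss. Compound 2 goes against a simple reading by ring size, since a 1.1-fold higher number from compound 2 to compound 3 (0.04 log units; within the scatter) leaves it level with compound 3. Adding the two fluorines to the cyclopentyl ring gave a 1.9-fold higher number from compound 1 to compound 2 (0.28 log units; within the scatter), so no clear gain can be credited to them.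

A modest downward step is therefore expected, possibly not clearing the scatter: a 1.8-fold lower number from compound 3 to compound 4 (0.25 log units; within the scatter). The estimate for compound 4 is 100000 nM, with an expected range of 40000 nM to 200000 nM.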

Compound 4, solubility: 93000 nM
Compound 4: the middle estimate sits 1.1-fold (0.03 log units) above what was measured; the range from low to high includes it.
By their numbers in this assay, from the lowest: compounds 1, 4, 2 and 3 (each within the scatter of the next, the first and the last beyond it).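

Among the compounds shown here, compound 4 puts a six-membered ring at this position, on the aromatic carbon between two ring nitrogen atoms, and in this assay no step to it clears the scatter (a 1.9-fold lower number from compound 3 to compound 4 (0.28 log units; within the scatter); a 1.8-fold lower number from compound 2 to compound 4 (0.24 log units; within the scatter); a 1.1-fold higher number from compound 1 to compound 4 (0.04 log units; within the scatter)). For the compounds shown here, the position therefore accepts 4,4-difluorocyclohexyl, with 8 heavy atoms, in place of 1-methylcyclopropyl, with 4 heavy atoms, without a step that can be read as real, and the only pair in the set printed as beyond the scatter remains compound 1 and compound 3. Neither ring size nor the presence of fluorine sorts these four compounds, as compound 2 and compound 4 both carry two fluorines yet each lies within the scatter of compound 3, and the data offer no measured explanation for the small differences that remain.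

Going by these compounds, all four groups at this position are carbon-only rings, so it remains open whether an amine, a carboxylic acid or a ring containing oxygen here would give a step in this assay that clears the scatter. On these data alone, the trifluoromethyl group and the shared core are also constant across these compounds, so the effect of replacing either one remains open.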